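Sulfonylpiperazine Variant of the Chloro Analogue

The compounds below may be only part of what the source reports. "The series", "measured", "known", "first", "only" and "open" are said of these compounds alone.

Compound 2 `CCC1(O)CCN(c2nc(C)c3cc(NC(=O)COc4ccc(Cl)cc4)ccc3n2)CC1` gives 384 nM in a functional assay on CHO-K1 cells for antagonist activity at melanin-concentrating hormone receptor 1 (Homo sapiens), read by inositol phosphate accumulation (on this read-out lower numbers stand for stronger inhibition and higher numbers for weaker inhibition), the highest number among the three measured compounds. Compound 1 `CCC1(O)CCN(c2nc(C)c3cc(NC(=O)COc4ccc(OC(F)(F)F)cc4)ccc3n2)CC1` gives 59 nM and compound 3 `Cc1nc(N2CCN(C(=O)C3CC3)CC2)nc2ccc(NC(=O)COc3ccc(OC(F)(F)F)cc3)cc12` gives 30 nM. The step of a 6.5-fold higher number from compound 1 to compound 2 (0.81 log units; beyond the scatter) sets compound 2 apart from compound 1 by the chloro in place of the trifluoromethoxy, and the step of a 2.0-fold lower number from compound 1 to compound 3 (0.29 log units; within the scatter) is within the scatter, so the exchange of the amine on the shared core has so far changed little.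

Compound 4 `Cc1nc(N2CCN(S(C)(=O)=O)CC2)nc2ccc(NC(=O)COc3ccc(Cl)cc3)cc12` is not yet measured. It differs from compound 2 in one place: 4-(methylsulfonyl)piperazin-1-yl in place of 4-ethyl-4-hydroxypiperidin-1-yl on an aromatic carbon. Among the measured compounds shown here, the only step that bears on this is the one from compound 1 to compound 3, which removes the same 4-ethyl-4-hydroxypiperidin-1-yl for a piperazine and stays within the scatter. For the measured compounds named here, no measured compound carries the methylsulfonyl group, so the expectation rests on that single step. The step from compound 2 to compound 4 is therefore expected to be small, a 1.5-fold lower number from compound 2 to compound 4 (0.19 log units; within the scatter), leaning slightly to a lower number. Compound 4 is estimated at 250 nM, with an expected range from 80 nM to 800 nM.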

Compound 4, half-maximal inhibitory concentration: > 10000 nM
Compound 4 was reported as a limit; the forecaster's own chance of this, stated with the estimate: 5%; middle value at least 40-fold (1.60 log units) from the limit.
By their numbers in this assay, from the lowest: compounds 3 and 1 (each within the scatter of the next); then compound 2. At a limit, above all of these: compound 4.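

The reading of compound 4 in this assay is a limit of the assay and not a number: the limit of > 10000 nM in this assay, at which 1 of the 4 values shown sits.
At this position, 4-(methylsulfonyl)piperazin-1-yl in place of 4-ethyl-4-hydroxypiperidin-1-yl gives an at least 26-fold higher number from compound 2 to compound 4 (1.41 log units; beyond the scatter), whereas 4-(cyclopropylcarbonyl)piperazin-1-yl in the same place gave a 2.0-fold lower number from compound 1 to compound 3 (0.29 log units; within the scatter).
The position is therefore not indifferent to the amine it carries, and a piperazine there can go with either outcome, depending on the rest of the compound.

Still open, as far as these compounds go, is whether the loss belongs to the methylsulfonyl group itself or to its pairing with the chloro, as the two piperazine steps differ in both features. Also open, from the compounds shown here alone, is how 4-acetylpiperazin-1-yl or an unsubstituted piperazin-1-yl would read in this place.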